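A few compounds are considered here, and "the series" means these few. Any claim that something is new, unique, unknown or untested is made for them only; others in the source may bear on it.

The three measured compounds share one core and differ only in the group on a carbonyl carbon. Compound 1 `Cn1ncc([N+](=O)[O-])c1C(=O)Nc1ccc2nc(NC(=O)C3CCCCC3)sc2c1` carries a 1-methyl-4-nitro-1H-pyrazol-5-yl there, and in a functional assay on WI-38 VA13 cells (Homo sapiens) for cytotoxicity (on this read-out higher numbers stand for an effect only at larger amounts of compound and lower numbers for an effect already at smaller amounts), compound 1 gives 0.026 ug/mL. Compound 3 `O=C(Nc1ccc2nc(NC(=O)C3CCCCC3)sc2c1)c1c(Cl)cccc1Cl` carries a 2,6-dichlorophenyl, and in this assay compound 3 gives 0.015 ug/mL; between them lies a 1.7-fold lower number from compound 1 to compound 3 (0.24 log units; within the scatter). For compound 2 `O=C(Nc1ccc2nc(NC(=O)C3CCCCC3)sc2c1)c1ccc(Br)cc1`, with a 4-bromophenyl, this assay reports only a limit, > 4 ug/mL. Compound 3 thus holds the lowest of the two numbers, with compound 1 nearest to it, while an at least 150-fold higher number from compound 1 to compound 2 (2.18 log units; beyond the scatter) and an at least 260-fold lower number from compound 2 to compound 3 (2.42 log units; beyond the scatter) are both large.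

Compound 4 `CC(=O)Nc1ccc2nc(NC(=O)C3CCCCC3)sc2c1` differs from compound 3 by methyl in place of 2,6-dichlorophenyl on a carbonyl carbon. Among the compounds with values here, no measured step removes the aromatic ring altogether; the nearest guides are the two exchanges of that ring, one of which, an at least 260-fold lower number from compound 2 to compound 3 (2.42 log units; beyond the scatter), was large, while the other, a 1.7-fold lower number from compound 1 to compound 3 (0.24 log units; within the scatter), stayed within the scatter. A loss is therefore expected for compound 4, though its size is uncertain: the estimate is 3 ug/mL, between 0.2 ug/mL and 20 ug/mL, meaning a 200-fold higher number from compound 3 to compound 4 (2.30 log units; beyond the scatter).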

Compound 4, half-maximal effective concentration: 2.7 ug/mL
For compound 4 the middle estimate is 1.1-fold (0.05 log units) above the measured one; the range from low to high includes it.
By their numbers in this assay, from the lowest: compounds 3 and 1 (each within the scatter of the next); then compound 4. At a limit, above all of these: compound 2.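

Methyl on the carbonyl carbon brings two large steps in this assay, a 180-fold higher number from compound 3 to compound 4 (2.26 log units; beyond the scatter) and a 100-fold higher number from compound 1 to compound 4 (2.02 log units; beyond the scatter), so the shared core with a bare carbonyl does not by itself give the low numbers of compound 1 and compound 3. Those numbers depend on the group at this place, and the loss of the 2,6-dichlorophenyl ring shows this from the side of a small group with no ring, while compound 2 goes against any rule that a ring alone is enough. The remaining step is an at least 1.4-fold lower number from compound 2 to compound 4 (0.17 log units; that floor lies within the scatter). Its full size cannot be read because compound 2 stands at a limit: the limit of > 4 ug/mL in this assay, at which 1 of the 4 values shown sits.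

The compounds shown leave open how an unsubstituted phenyl would behave at this place. They also leave open what a longer chain or an amine on this carbonyl carbon would give.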